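The compounds below may be only part of what the source reports. "The series", "measured", "known", "first", "only" and "open" are said of these compounds alone.

Going by the values given here, compound 2 `CCc1csc(S(=O)(=O)NC(=O)Nc2ccc(Cl)cc2)c1` stands highest of the two numbers so far in a functional assay on the whole organism (6C3HED cells, Mus musculus) for inhibition, at a dose of 300 mg/kg by the oral route (a higher number here means more inhibition at the dose given (going by the name of the read-out), a lower number less inhibition), where compound 2 gives 93%. Its parent, compound 1 `O=C(Nc1ccc(Cl)cc1)NS(=O)(=O)c1cccs1`, gives 66% in this assay. Among the compounds with values here, the one measured step, a number 27 percentage points higher from compound 1 to compound 2 (beyond the scatter), came with ethyl in place of hydrogen on an aromatic carbon, and it lies beyond the scatter.

Compound 3 `COc1csc(S(=O)(=O)NC(=O)Nc2ccc(Cl)cc2)c1` differs from compound 2 by methoxy in place of ethyl on an aromatic carbon. Within the data shown here, no measured step exchanges one group for another at that carbon; the only step that bears on the place is a number 27 percentage points higher from compound 1 to compound 2 (beyond the scatter), which shows that a group there, rather than hydrogen, went with a modest rise. Among the measured compounds shown here, whether methoxy carries the same rise as ethyl cannot be read from two compounds, so the expectation for compound 3 sits between the two known numbers, weighted toward compound 2. The step expected is a number 11 percentage points lower from compound 2 to compound 3 (beyond the scatter), which is small and may fall within the scatter. Compound 3 is therefore estimated to give 82%, within a range of 58% to 97%.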

Compound 3, a percentage reported as inhibition, in the whole organism at one dose (the size of the read-out at that dose, not a potency): 69%
Estimate against measurement, compound 3: 13 percentage points above; low and high end bracket the measured number.
By their numbers in this assay, from the lowest: compounds 1 and 3 (each within the scatter of the next); then compound 2.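

The position now has its first exchange of one group for another: in this assay there is a number 24 percentage points lower from compound 2 to compound 3 (beyond the scatter), so the rise seen with ethyl does not follow from just any group standing on that aromatic carbon. Methoxy also does not separate from hydrogen at this place, with a number 3 percentage points higher from compound 1 to compound 3 (within the scatter), which leaves ethyl as the only one of the two groups shown that stands apart from the parent. The two groups have the same count of heavy atoms and differ in that methoxy brings an oxygen in place of a carbon and a hydrogen-bond acceptor, so a change of this size in the read-out can come with an exchange that leaves the heavy-atom count the same. Nothing measured here accounts for the gap between ethyl and methoxy at this carbon.

Going by these compounds, whether a longer chain such as propyl, a halogen such as chlorine or an amine at this place would follow ethyl or methoxy stays open. On these data alone, the read-out also comes from a single dose, so how the three compounds would compare at other doses remains open as well.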